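Compound 3: ethyl in place of hydrogen, clearance estimate

The source may report more compounds than this note shows. Statements on the series, on what has been measured and on what is new or still open speak of the compounds shown alone.

In an ADME assay on microsomes from liver (Mus musculus) for metabolic stability, read by LC-MS, using NADPH, with stated times of 10 min and 30 min (a higher number here means faster removal of the compound, a lower number slower removal), compound 1 (`CCC(=O)N[C@@H]1CCCc2c1cncc2N1C(=O)c2ccc(Cl)cc2[C@@H]1CC`) gives < 20.2 mL/min/kg, which is a limit and not a number. Compound 2 (`CC(=O)N[C@@H]1CCCc2c1cncc2N1Cc2cc(Cl)ccc2C1=O`) gives < 20.2 mL/min/kg, also a limit, so its standing is known only as a limit. Compound 3 (`CC[C@H]1c2cc(Cl)ccc2C(=O)N1c1cncc2c1CCC[C@H]2NC(C)=O`) differs from compound 2 by ethyl in place of hydrogen on a saturated ring carbon. Going by the values given here, no measured step covers this change. In this assay, the expected change is none beyond the scatter, an estimated step that the limit leaves unreadable from compound 2 to compound 3. The estimate for compound 3 is 20 mL/min/kg, with an expected range of 13 mL/min/kg to 36 mL/min/kg.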

Compound 3, clearance: < 20.2 mL/min/kg
Compound 3 gave a limit, no number; the forecaster's own chance of this, stated with the estimate: 65%; the middle value is on the limit's open side.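

No step can be read from compound 2 or compound 1 to compound 3 in this assay, because each value is a limit and not a number: the limit of < 20.2 mL/min/kg in this assay, at which 3 of the 3 values shown sit.

On these data alone, the actual clearance of all three compounds, and what ethyl in place of hydrogen on a saturated ring carbon does to it, stay open.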